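Urea series: replacing the sulfamoyl group with hydrogen

This account rests on a few compounds, and the source may have more. Where it says the series, first, only, none or still open, it means among the compounds named here.

In a functional assay on MCF7 cells (Homo sapiens) for inhibition (on this read-out higher numbers stand for weaker inhibition and lower numbers for stronger inhibition), compound 1 `N#CC1CN1C(=O)Nc1ccc(S(N)(=O)=O)cc1` reports only a limit, > 15000 nM. Compound 2 `CCOC(=O)CNC(=O)N1CC1C#N` gives 17000 nM in this assay, and compound 3 `N#CC1CN1C(=O)NC1CCCCC1` gives 8900 nM in this assay. Compound 2 and compound 3 lie within the usual scatter of each other, so no order can be set between them. Compound 1 stands apart only in that its result is a limit rather than a number (the limit of > 15000 nM in this assay, at which 1 of the 3 values shown sits); all three compounds sit in the weak range of this assay.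

Compound 4 `N#CC1CN1C(=O)Nc1ccccc1` differs from compound 1 in one place: hydrogen in place of sulfamoyl on an aromatic carbon. Going by the values given here, no pair of measured compounds differing in a single place is available, so no measured step guides this change. With every measured compound weak, the step from compound 1 to compound 4 is expected to stay within the usual scatter or to move weakly, an at least 1.5-fold lower number from compound 1 to compound 4 (0.17 log units; that floor lies within the scatter). Compound 4 is therefore estimated at 10000 nM in this assay, with a likely range from 3000 nM to 30000 nM.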

Compound 4, half-maximal inhibitory concentration: 2600 nM
Beside the measured number, compound 4's estimate is 3.8-fold (0.59 log units) above it, and the stated range ends above it.
By their numbers in this assay, from the lowest: compound 4; then compounds 3 and 2 (each within the scatter of the next).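

Hydrogen in place of sulfamoyl on an aromatic carbon gives in this assay an at least 5.7-fold lower number from compound 1 to compound 4 (0.76 log units; beyond the scatter) and so supplies the first measured step of the series. Compound 4 thus shows that the read-out does not depend on the sulfamoyl group, and that this place on the aromatic ring, para to a group of 8 heavy atoms, is one where a change moves the number. The true size of the step stays unknown because compound 1 carries only a limit: the limit of > 15000 nM in this assay, at which 1 of the 4 values shown sits.

With hydrogen the only replacement shown, it stays open whether any group at this place can match compound 4 or whether the ring must stay bare. An amine, a carboxylic acid or a methyl group on the same aromatic carbon would separate these readings.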